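Swapping sulfamoyl for acetamido on a shared core

The compounds below may be only part of what the source reports. "The series", "measured", "known", "first", "only" and "open" are said of these compounds alone.

Compound 1 `NS(=O)(=O)c1ccc(Nc2nccc(-c3cccnc3)n2)cc1` and compound 2 `CC(=O)Nc1ccc(Nc2nccc(-c3cccnc3)n2)cc1` share a core and differ in one group: acetamido in place of sulfamoyl on an aromatic carbon. In a functional assay for inhibition, with Homo sapiens as the target (on this read-out higher numbers stand for weaker inhibition and lower numbers for stronger inhibition), compound 1 gives 200 nM, while compound 2 gives 3600 nM, so this change produced an 18-fold higher number from compound 1 to compound 2 (1.26 log units; beyond the scatter). Compound 3 `NS(=O)(=O)c1cccc(Nc2nccc(-c3cccnc3)n2)c1` has the same atoms as compound 1 joined differently; the difference between the two cores is not broken down here. In this assay compound 3 gives 200 nM, level with compound 1 at the digits shown. Compound 4 `CC(=O)Nc1cccc(Nc2nccc(-c3cccnc3)n2)c1` carries the same kind of change relative to compound 3: acetamido in place of sulfamoyl on an aromatic carbon, here meta to a large group rather than para to a large group. Because the same kind of change gave an 18-fold higher number from compound 1 to compound 2 (1.26 log units; beyond the scatter), a step of comparable size, a 15-fold higher number from compound 3 to compound 4 (1.18 log units; beyond the scatter), is expected. For compound 4 the estimate is 3000 nM, with a range from 1000 nM to 9000 nM.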

Compound 4, half-maximal inhibitory concentration: 3600 nM
Compound 4: middle estimate off by 1.2-fold (0.08 log units), on the low side; the range from low to high includes it.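

In this assay, putting acetamido in place of sulfamoyl gives an 18-fold higher number from compound 3 to compound 4 (1.26 log units; beyond the scatter), and the two cores respond alike: the same change on two cores in this assay, an 18-fold higher number (1.26 log units; beyond the scatter) from compound 1 to compound 2 and an 18-fold higher number (1.26 log units; beyond the scatter) from compound 3 to compound 4, 1.0-fold (0.00 log units) apart, within the scatter of two such steps. In these two pairs, then, the change carries over between the core of compound 1, where the group sits para to a large group, and the core of compound 3, where it sits meta to a large group. Two pairs show nothing about why the number rises, and they cannot show that the step would hold on any other core.

The compounds shown leave open how other groups at this place would read, such as an amine or a carboxylic acid. Also open, going by these compounds, is whether a change elsewhere on the shared core would alter the size of this step.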